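The source may hold more compounds than are shown below. What is called first, only, known or untested is meant among the compounds shown, and "the series" means these compounds.

Measured so far in a physicochemical assay for lipophilicity, measured as octanol-water partition; a lower number here means a more polar compound, a higher number a more lipophilic compound:
- Compound 1 `CC1=C(C(=O)OCc2cccnc2)C(c2ccco2)C2=C(CCCC2=O)N1` gives 1.03
- Compound 2 `CC1=C(C(=O)OCc2cccnc2)C(c2cccc(O)c2)C2=C(CCCC2=O)N1` gives 1.21
- Compound 3 `CC1=C(C(=O)OCc2cccnc2)C(c2ccccc2)C2=C(CCCC2=O)N1` gives 2.35

Of these three, compound 3 has the highest number (at 2.35), beyond the scatter from both others. Compound 4 `CC1=C(C(=O)OCc2cccnc2)C(c2ccccc2[N+](=O)[O-])C2=C(CCCC2=O)N1` has nitro in place of hydrogen on an aromatic carbon, ortho to a large group (nitro in place of hydrogen on an aromatic carbon). Within the data shown here, no measured step involves nitro. The closest guide is the large change on an aromatic carbon when hydrogen replaces hydroxy (a number 1.14 log units higher from compound 2 to compound 3 (beyond the scatter)). Replacing the whole ring gave a similarly large step (a number 1.32 log units higher from compound 1 to compound 3 (beyond the scatter)) but bears less directly. Only a small fall in this assay is expected (a number 0.15 log units lower from compound 3 to compound 4 (within the scatter)), possibly within the scatter. The estimate for compound 4 is 2.2 (expected range 1.75 to 2.65).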

Compound 4, partition coefficient: 1.51
For compound 4 the middle estimate is 0.69 log units above the measured one, outside the stated range (below it).
By their numbers in this assay, from the lowest: compounds 1, 2 and 4 (each within the scatter of the next, the first and the last beyond it); then compound 3.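

In this assay, nitro in place of hydrogen on an aromatic carbon, ortho to a large group, gives a real fall (a number 0.84 log units lower from compound 3 to compound 4 (beyond the scatter)). This places the 2-nitrophenyl compound within the scatter of the 3-hydroxyphenyl compound (a number 0.30 log units higher from compound 2 to compound 4 (within the scatter)), yet still apart from the furan-2-yl compound (a number 0.48 log units higher from compound 1 to compound 4 (beyond the scatter)). Nothing available explains the size of this fall. Open still is whether an amine or a carboxylic acid on this same carbon would shift the number as far, and whether nitro elsewhere on the phenyl ring would do the same.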